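The source may report more compounds than this note shows. Statements on the series, on what has been measured and on what is new or still open speak of the compounds shown alone.

Compound 1 `O=C(O)CN1C(=O)/C(=C/C2=Cc3cc(Br)ccc3OC2)SC1=S`, compound 2 `CC1Oc2ccc(Br)cc2C=C1/C=C1\SC(=O)NC1=O` and compound 3 `CC1Oc2ccc(Br)cc2C=C1/C=C1\SC(=O)N(C)C1=O` share a core and have been tested in a functional assay on MOLT-4 cells (Homo sapiens) for antiproliferative activity, read by MTT assay, with a stated time of 72 h; a higher number here means a weaker inhibitor, a lower number a stronger inhibitor. In this assay compound 2 gives 64500 nM. Compound 1 reaches only a limit of the assay, > 25000 nM, so no number is known for it. Compound 3 likewise reaches only a limit, > 50000 nM, as recorded by the limit of > 50000 nM in this assay, at which 1 of the 3 values shown sits. The measured step that the limit leaves unreadable from compound 2 to compound 3 therefore cannot be read. Compound 4 `CCN1C(=O)S/C(=C\C2=Cc3cc(Br)ccc3OC2C)C1=O` differs from compound 3 by methyl in place of hydrogen on a saturated chain carbon bound to an amide-type nitrogen in a ring. Within the data shown here, no measured step of this kind exists, and the one neighbouring step is unreadable, so compound 4 is expected to remain weak. The estimate for compound 4 is 70000 nM, between 25000 nM and 200000 nM. The expected step that the limit leaves unreadable from compound 3 to compound 4 is not beyond the scatter.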

Compound 4, half-maximal inhibitory concentration: > 100000 nM
Compound 4 ended at the assay's limit; the forecaster's own chance of this, stated with the estimate: 70%; middle value at least 1.4-fold (0.15 log units) away from the limit.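

In this assay, ethyl in place of hydrogen on the amide-type nitrogen in a ring gives an at least 1.5-fold higher number from compound 2 to compound 4 (0.19 log units; that floor lies within the scatter), so this floor alone does not establish a real weakening. Compound 4 reaches only a limit of the assay, > 100000 nM. With methyl in compound 3 and ethyl in compound 4, this nitrogen carries two groups that both end at limits, and the steps that involve only limits cannot be read.

Going by these compounds, whether a propyl chain or a chain ending in an amine at this place would give a measurable number stays open.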